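A few compounds are considered here, and "the series" means these few. Any claim that something is new, unique, unknown or untested is made for them only; others in the source may bear on it.

Compound 1 `CCOC(=O)CCCCCOc1ccc2c(=O)c(-c3ccc(O)cc3)coc2c1` and compound 2 `O=C(O)CCCCCCCOc1ccc2c(=O)c(-c3ccc(O)cc3)coc2c1` share one core and differ only at the far end of a chain attached through an oxygen on an aromatic ring. In an assay (Cricetulus griseus) for inhibition of Monoamine oxidase (Homo sapiens) (on this read-out higher numbers stand for weaker inhibition and lower numbers for stronger inhibition), compound 1 gives 5300 nM, and in the same assay compound 2 gives 6500 nM. Compound 2 carries the higher of the two numbers, but the gap is small: the step of a 1.2-fold higher number from compound 1 to compound 2 (0.09 log units; within the scatter) lies within the usual scatter, so the two compounds cannot be told apart on this read-out.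

Compound 3 `C=CCCCCOc1ccc2c(=O)c(-c3ccc(O)cc3)coc2c1` is the next member. Relative to compound 2 the change is vinyl in place of 3-carboxypropyl on a saturated chain carbon, four bonds along the chain from an oxygen on an aromatic ring: the chain is cut short and the acid group at its end disappears. Only one measured step bears on this, the change from compound 1 to compound 2, and it was flat, so the end of the chain has so far shown little influence. The step of a 1.3-fold lower number from compound 2 to compound 3 (0.11 log units; within the scatter) is therefore expected to stay small, with no clear direction beyond the scatter. For compound 3 in this assay the estimated value is 5000 nM, with a plausible range from 1500 nM to 16000 nM.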

Compound 3, half-maximal inhibitory concentration: 5000 nM
Beside the measured number, compound 3's estimate shows no gap at the digits printed; the range from low to high includes it.
By their numbers in this assay, from the lowest: compounds 3, 1 and 2 (each within the scatter of the next).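

In this assay, the step of a 1.3-fold lower number from compound 2 to compound 3 (0.11 log units; within the scatter) and the step of a 1.1-fold lower number from compound 1 to compound 3 (0.03 log units; within the scatter) show that a chain ending in a vinyl group cannot be told apart from the acid of compound 2 or the ester of compound 1. This test is broader than the earlier comparison, which set only two chain ends containing a carbonyl against each other: here 3-carboxypropyl, with 6 heavy atoms, 1 hydrogen-bond donor and 1 hydrogen-bond acceptor, gives way to vinyl, with 2 heavy atoms and 0 of either, and the read-out still stays within the scatter. No separate measurement offers an explanation for this flat result.

With all three compounds within the scatter of one another, the set does not show whether any change at the end of the chain can move the number beyond the scatter. An amine or a phenyl ring at the end of the chain, or a much shorter chain, would be the next groups to test that question.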